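The compounds below may be only part of what the source reports. "The series", "measured", "known", "first", "only" and "open" are said of these compounds alone.

For the measured compounds named here, compound 2 `CC(Oc1ccccc1Cl)c1nc(N)nc(N2CCN(C)CC2)n1` is one of only two compounds measured in a functional assay on cells for antagonist activity at 5-hydroxytryptamine receptor 6 (Homo sapiens), read by luminescence and calcium flux, with a stated time of 30 min, in the presence of a further agent that is not named here; a higher number here means a weaker inhibitor, a lower number a stronger inhibitor. Compound 2 gives 3 nM. Compound 1 `Cc1ccc(C(C)C)c(OCc2nc(N)nc(N3CCN(C)CC3)n2)c1` gives 4.6 nM in this assay, a number that lies within the scatter of the value for compound 2, so no order between the two can be read from these data. Compound 3 `CC(Sc1ccccc1Cl)c1nc(N)nc(N2CCN(C)CC2)n1` has not yet been measured. It differs from compound 2 by (2-chlorophenyl)sulfanyl in place of 2-chlorophenoxy on a saturated chain carbon bound to an aromatic carbon and a saturated chain carbon. Going by the values given here, no step between measured compounds bears directly on this change, and neither measured compound carries a sulfur-linked group of this kind. A step not larger than the scatter is expected, with at most a modest weakening. For compound 3 the expected step is a 1.5-fold higher number from compound 2 to compound 3 (0.18 log units; within the scatter). Compound 3 is therefore expected to give about 4.5 nM in this assay, within a range from 1.5 nM to 14 nM.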

Compound 3, antagonist equilibrium constant: 2.9 nM
Estimate against measurement, compound 3: 1.6-fold (0.19 log units) above; low and high end bracket the measured number.
By their numbers in this assay, from the lowest: compounds 3, 2 and 1 (each within the scatter of the next).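

In this assay, for the compounds shown here, the exchange of 2-chlorophenoxy for (2-chlorophenyl)sulfanyl on a saturated chain carbon bound to an aromatic carbon and a saturated chain carbon gives a 1.0-fold lower number from compound 2 to compound 3 (0.01 log units; within the scatter) and is the first direct comparison at this position, which the earlier compounds could not supply. It shows that, with the rest of the molecule unchanged, oxygen and sulfur as the linking atom cannot be told apart in this read-out. Nothing at hand speaks to the reason for this outcome.

What the compounds shown leave open is whether this indifference extends to other links at the same place, such as an amine or a sulfonyl group. They also do not tell whether it would hold with a group other than the 2-chlorophenyl ring on the sulfur.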